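Chloro on the benzoyl of a hydrazide sulfonamide

The source may hold more compounds than are shown below. What is called first, only, known or untested is meant among the compounds shown, and "the series" means these compounds.

Measured so far:
compound 1, `NS(=O)(=O)c1cccc(-c2nnc(-c3ccc(Cl)cc3)o2)c1`: > 100000 nM
compound 2, `NS(=O)(=O)c1ccc(C(=O)NNC(=O)c2ccccc2)cc1`: 62800 nM

In an assay on cells for inhibition of Amine oxidase [flavin-containing] A (Homo sapiens), read by fluorescence and spectrophotometry, using microsomes, with a stated time of 20 min (on this read-out lower numbers stand for stronger inhibition and higher numbers for weaker inhibition), compound 1 reaches only the limit of the assay, > 100000 nM, and no number. In this assay, within the data shown here, compound 2 gives 62800 nM, the only number the set holds. The other value shown, that of compound 1, is a limit: the limit of > 100000 nM in this assay, at which 1 of the 2 values shown sits. Compound 2 therefore stands alone as the single measured point, with nothing of the same series to compare it against.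

Compound 3, `NS(=O)(=O)c1ccc(C(=O)NNC(=O)c2ccc(Cl)cc2)cc1`, differs from compound 2 in one place: chloro in place of hydrogen on an aromatic carbon. Among the measured compounds shown here, no step between two measured compounds is available, so the size of the step in this assay can only be guessed. The change is small, one heavy atom on an aromatic ring, and any step from compound 2 to compound 3 is expected to stay within the usual scatter, without a clear direction. Compound 3 is accordingly estimated at 50000 nM, with a range from 15000 nM to 150000 nM, which means an expected step of a 1.3-fold lower number from compound 2 to compound 3 (0.10 log units; within the scatter).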

Compound 3, half-maximal inhibitory concentration: 55900 nM
The estimate for compound 3 lay 1.1-fold (0.05 log units) below the measured number; low and high end bracket the measured number.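

Among these compounds, the change from phenyl to 4-chlorophenyl gives the first step that can be read in this assay: a 1.1-fold lower number from compound 2 to compound 3 (0.05 log units; within the scatter). At this aromatic carbon, para to a large group, one chlorine therefore leaves the read-out within the scatter, and compound 2 and compound 3 cannot be told apart on these numbers. Nothing shown gives a cause for this result.

Going by these compounds, whether an amine, a carboxylic acid or a methoxy group on the same carbon would produce a step beyond the scatter remains open, and so does the question of whether any group there can do so. Compound 1 stands at a limit, > 100000 nM, and so offers no number to set against the others.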